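Aryl amine swap on the shared core: compound 3

This account rests on a few compounds, and the source may have more. Where it says the series, first, only, none or still open, it means among the compounds named here.

Compound 1 `C=CC(=O)Nc1cccc(NC(=O)CSc2nc(Nc3ccccc3Br)c3ccccc3n2)c1` and compound 2 `C=CC(=O)Nc1cccc(NC(=O)CSc2nc(Nc3ccc(CC)cc3)c3ccccc3n2)c1` share a core and differ only in the aryl group on the nitrogen on the aromatic ring. In a functional assay on MGC-803 cells (Homo sapiens) for inhibition, read by MTT assay, with a stated time of 72 h (a lower number here means a stronger inhibitor, a higher number a weaker inhibitor), compound 1 gives 12800 nM and compound 2 gives 8010 nM; the step of a 1.6-fold lower number from compound 1 to compound 2 (0.20 log units; within the scatter) leaves the two numbers indistinguishable, so compound 2 stands beside compound 1 rather than apart from it. Compound 3 `C=CC(=O)Nc1cccc(NC(=O)CSc2nc(Nc3ccc(F)c(Cl)c3)c3ccccc3n2)c1` carries 3-chloro-4-fluorophenyl in place of 4-ethylphenyl on a nitrogen on an aromatic ring. Within the data shown here, only the step from compound 1 to compound 2 bears on this change, as it also swaps the aryl group on that nitrogen, and it stayed within the scatter; no measured step tests a halogenated aryl group here. In this assay compound 3 is expected to sit near compound 2, with a step of a 1.0-fold lower number from compound 2 to compound 3 (0.00 log units; within the scatter) not beyond the scatter. The estimate for compound 3 is 8000 nM, with a range from 3000 nM to 22000 nM.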

Compound 3, half-maximal inhibitory concentration: 7850 nM
The estimate for compound 3 lay 1.0-fold (0.01 log units) above the measured number, within the range that was stated.
By their numbers in this assay, from the lowest: compounds 3, 2 and 1 (each within the scatter of the next).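

In this assay, a halogenated aryl group on this nitrogen can now be read: the step of a 1.0-fold lower number from compound 2 to compound 3 (0.01 log units; within the scatter) and the step of a 1.6-fold lower number from compound 1 to compound 3 (0.21 log units; within the scatter) show 3-chloro-4-fluorophenyl reading alike with both 4-ethylphenyl and 2-bromophenyl. Across these three aryl groups, the position on a nitrogen on an aromatic ring shows no change beyond the scatter, whether the aryl group carries an ethyl group, one halogen or two. No measurement at hand explains this flat reading.

As far as these compounds go, whether a carboxylic acid or a dimethylamino group on the aryl ring would move the number beyond the scatter remains open, as does the effect of a longer alkyl chain in place of the aryl group. The three compounds also share the rest of the structure, so they say nothing about changes elsewhere on the shared core.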